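The source may report more compounds than this note shows. Statements on the series, on what has been measured and on what is new or still open speak of the compounds shown alone.

Measured compounds in a functional assay on MDA-MB-231 cells (Homo sapiens) for inhibition, read by sulforhodamine B assay; on this read-out higher numbers stand for weaker inhibition of growth and lower numbers for stronger inhibition of growth:

compound 1, `O=C(CCC1=CCN(CCCc2ccc(Cl)cc2)C1=O)NO`: 2210 nM
compound 2, `Cc1cccc(CCCN2CC=C(CCC(=O)NO)C2=O)c1`: 2210 nM

Compound 1 stands level with compound 2; the step of no change at the digits printed from compound 1 to compound 2 (within the scatter) shows that swapping the aryl substituent on the chain leaves this assay unmoved. Compound 3, `CC(C)c1ccc(CCCN2CC=C(CCC(=O)NO)C2=O)cc1`, differs from compound 1 as follows: isopropyl in place of chloro on an aromatic carbon. Among the compounds with values here, no measured step covers this exact exchange; the only related step, no change at the digits printed from compound 1 to compound 2 (within the scatter), was flat. The expected step of a 1.0-fold lower number from compound 1 to compound 3 (0.00 log units; within the scatter) is therefore none beyond the scatter. Compound 3 is estimated at 2200 nM, within 1000 nM to 5000 nM.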

Compound 3, concentration for 50% growth inhibition: 2210 nM
Estimate against measurement, compound 3: 1.0-fold (0.00 log units) below; the measured number falls inside the stated range.
By their numbers in this assay, from the lowest: compounds 1, 2 and 3 (each within the scatter of the next).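

Isopropyl in place of chloro, on an aromatic carbon para to a large group, gives no change at the digits printed from compound 1 to compound 3 (within the scatter) in this assay. The earlier pair changed both the aryl substituent and its place, whereas this step keeps the place and puts 3 heavy atoms, all carbon, where 1 chlorine stood, and the number still holds. No measurement at hand accounts for this flatness.

As far as these compounds go, whether an amine or a carboxylic acid on this aromatic carbon would move the number remains open. So does the effect of a longer chain on the amide-type nitrogen.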